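The source may report more compounds than this note shows. Statements on the series, on what has been measured and on what is new or still open speak of the compounds shown alone.

The series shares the core of compound 1 `Cc1nc(C)c([C@H](OC(C)(C)C)C(=O)O)c(N2CCC(C)(C)CC2)c1-c1ccc(Cc2ccccc2)cc1`, with the variation on the aromatic ring that carries the benzyl or ethoxy arm. In a toxicity assay on MT2 cells (Homo sapiens) for cytotoxicity, read by XTT assay, with a stated time of 4 days (a higher number here means that more compound is tolerated, a lower number that less compound is tolerated), compound 1 gives >= 20000 nM, which is a limit of the measurement rather than a number. Compound 2 `Cc1nc(C)c([C@H](OC(C)(C)C)C(=O)O)c(N2CCC(C)(C)CC2)c1-c1ccc(OCCc2ccccn2)cc1` carries 2-(pyridin-2-yl)ethoxy in place of benzyl. In this assay compound 2 gives >= 25000 nM, again a limit. The step that the two limits leave unreadable from compound 1 to compound 2 therefore cannot be read, as both values sit at limits, recorded as the limit of >= 20000 nM in this assay, at which 1 of the 2 values shown sits, and (the limit of >= 25000 nM in this assay, at which 1 of the 2 values shown sits). Compound 2 thus stands at the edge of what this assay reports, with no numerical value of its own.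

Compound 3 `Cc1nc(C)c([C@H](OC(C)(C)C)C(=O)O)c(N2CCC(C)(C)CC2)c1-c1ccc(OCCc2ccncc2)cc1` differs from compound 2 by pyridin-4-yl in place of pyridin-2-yl on a saturated chain carbon, two bonds along the chain from an oxygen on an aromatic ring. Going by the values given here, no measured step separates the two pyridyl isomers, so the only bearing comes from the change between compound 1 and compound 2, which itself was unreadable. No step beyond the scatter is expected; the change is estimated at a number no higher from compound 2 to compound 3 (the limit leaves the size open). For compound 3 the expected value in this assay is 25000 nM, with a range from 15000 nM to 40000 nM, most likely again reported only as a limit.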

Compound 3, half-maximal cytotoxic concentration: >= 25000 nM
Compound 3: a limit, no number (the forecaster's own chance of this, stated with the estimate: 80%); the middle value lies on the limit itself.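

In this assay compound 3 gives >= 25000 nM, a limit and not a number. No step among compound 1, compound 2 and compound 3 can be read, because all three values sit at limits: the limit of >= 25000 nM in this assay, at which 2 of the 3 values shown sit.

The compounds shown leave open where the half-maximal cytotoxic concentration of each actually lies, and whether pyridin-2-yl and pyridin-4-yl differ at all.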